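Adding a methanesulfonamide to a thiazole acetic acid antagonist

The source may hold more compounds than are shown below. What is called first, only, known or untested is meant among the compounds shown, and "the series" means these compounds.

Measured compounds:
Compound 1, `Nc1nc(-c2ccc(Cl)cc2)c(CC(=O)O)s1`, in an in vitro functional assay on HEK285-7 cells for antagonist activity at prostaglandin D2 receptor 2 (Homo sapiens), read by BRET and beta-arrestin recruitment (a higher number here means a weaker inhibitor, a lower number a stronger inhibitor), compound 1 gives > 100000 nM, which is a limit of this assay rather than a number.
Compound 2, `O=C(O)Cc1sc(NC(=O)c2ccccc2)nc1-c1ccc(Cl)cc1`, in this assay compound 2 gives 870 nM.
Compound 3, `O=C(O)Cc1sc(C(c2ccc(F)cc2)c2ccc(F)cc2)nc1-c1ccccc1`, in this assay compound 3 gives 240 nM.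

Compound 3 holds the lowest of the two numbers shown; compound 2 has a higher number, and the third value, that of compound 1, is only a limit. Compound 4, `CS(=O)(=O)Nc1cccc(-c2nc(C(c3ccc(F)cc3)c3ccc(F)cc3)sc2CC(=O)O)c1`, differs from compound 3 by methanesulfonamido in place of hydrogen on an aromatic carbon.

Going by the values given here, only one step has been measured between compounds that differ in a single place: an at least 110-fold lower number from compound 1 to compound 2 (2.06 log units; beyond the scatter). That change sits on a nitrogen of the shared core, not on the phenyl ring, and it replaces a hydrogen with a very different group, so it gives no direct guide to the present change. With nothing closer to lean on, the expected step is a 1.2-fold lower number from compound 3 to compound 4 (0.08 log units; within the scatter), within the usual scatter. The value of compound 4 in this assay is therefore estimated at 200 nM, in the range 60 nM to 700 nM.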

Compound 4, half-maximal inhibitory concentration: 370 nM
Beside the measured number, compound 4's estimate is 1.9-fold (0.27 log units) below it; the measured number falls inside the stated range.
By their numbers in this assay, from the lowest: compounds 3 and 4 (each within the scatter of the next); then compound 2. At a limit, above all of these: compound 1.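

In this assay, placing methanesulfonamido on an aromatic carbon of the phenyl ring gives a 1.5-fold higher number from compound 3 to compound 4 (0.19 log units; within the scatter), so the two compounds cannot be told apart. Going by these compounds alone, this is the first look at a change on this ring, and it shows that this carbon can carry a group of this size, with its sulfur, nitrogen and two oxygens, without a change beyond the scatter. Within the data shown here, the only earlier single change, an at least 110-fold lower number from compound 1 to compound 2 (2.06 log units; beyond the scatter), was large, but it sat on a nitrogen of the shared core and says nothing about this ring.

On these data alone, whether an amine or an acetamide on the same carbon would also stay within the scatter remains open. The compounds shown give no reason for this result.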